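This account rests on a few compounds, and the source may have more. Where it says the series, first, only, none or still open, it means among the compounds named here.

Among the measured compounds shown here, in a functional assay on L02 cells (Homo sapiens) for inhibition, read by Griess assay, with stated times of 1 h and 24 h (a higher number here means a weaker inhibitor, a lower number a stronger inhibitor), no compound tested so far has given a readable number. Compound 1 `C(=C/c1ccco1)\c1nc(NCc2ccccc2)c2sccc2n1` gives > 1000000 nM, which is a limit and not a measured value. Compound 2 `Clc1ccc(CNc2nc(/C=C/c3ccco3)nc3ccsc23)cc1`, with chloro in place of hydrogen on an aromatic carbon, gives > 1000000 nM, again a limit. Compound 3 `Fc1ccc(CNc2nc(/C=C/c3ccco3)nc3ccsc23)cc1`, with fluoro in that place, gives > 1000000 nM, also a limit. For the measured compounds named here, compound 3 therefore has no exact standing among the others, and the series so far comes down to the limit of > 1000000 nM in this assay, at which 3 of the 3 values shown sit.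

Compound 4 `Fc1ccccc1CNc1nc(/C=C/c2ccco2)nc2ccsc12` keeps the same atoms but joins them differently: 2-fluorophenyl in place of 4-fluorophenyl on a saturated chain carbon bound to a nitrogen on an aromatic ring. In words, 2-fluorophenyl stands in place of 4-fluorophenyl on a saturated chain carbon bound to a nitrogen on an aromatic ring.

Going by the values given here, three measured steps bear on this change, though none has a size that can be read: a step that the two limits leave unreadable from compound 1 to compound 3, a step that the two limits leave unreadable from compound 1 to compound 2 and a step that the two limits leave unreadable from compound 2 to compound 3. None of these halogen changes produced a readable number in this assay, so nothing points to a shift in either direction. The expected change is none beyond the usual scatter, shown here as a number no higher from compound 3 to compound 4 (the limit leaves the size open). Another limit is the most likely result. For compound 4 the estimated value is 1000000 nM, with an expected range from 300000 nM to 3000000 nM.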

Compound 4, half-maximal inhibitory concentration: > 1000000 nM
Compound 4: a limit, no number; the forecaster's own chance of this, stated with the estimate: 85%; the middle value lies on the limit itself.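

Compound 4 gives a limit and not a number, so no step from compound 1, compound 2 or compound 3 to compound 4 can be read: the limit of > 1000000 nM in this assay, at which 4 of the 4 values shown sit.

The compounds shown leave open what exact number any of the four would give in this assay, and so whether the chloro and fluoro changes make any difference there.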